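The compounds below may be only part of what the source reports. "The series", "measured", "known", "first", "only" and "open" are said of these compounds alone.

Measured in a functional assay on MCF7 cells (Homo sapiens) for cytotoxicity, read by MTT assay, with a stated time of 72 h; a higher number here means a weaker inhibitor, a lower number a stronger inhibitor:
compound 1 `FC(F)(F)c1ccc(CSc2nc(Nc3ccc(Cl)cc3)c3ccccc3n2)cc1` gives 21500 nM.
compound 2 `COc1ccc(Nc2nc(SCc3ccc(C(F)(F)F)cc3)nc3ccccc23)cc1` gives 47200 nM.
compound 3 `CCOc1ccc(Nc2nc(SCc3ccc(C(F)(F)F)cc3)nc3ccccc23)cc1` is reported only as a limit of the assay, > 50000 nM.

Compound 3 thus stands at the floor of the set (the limit of > 50000 nM in this assay, at which 1 of the 3 values shown sits), with no number of its own. Against compound 1 the step reads an at least 2.3-fold higher number from compound 1 to compound 3 (0.36 log units; beyond the scatter); against compound 2 it reads an at least 1.0-fold higher number from compound 2 to compound 3 (0.02 log units; that floor lies within the scatter), which settles nothing about order between compound 2 and compound 3.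

Compound 4 `COc1ccc(Nc2nc(SCc3ccc(C(F)(F)F)cc3)nc3ccccc23)c(OC)c1` differs from compound 3 by 2,4-dimethoxyphenyl in place of 4-ethoxyphenyl on a nitrogen on an aromatic ring. The measured steps that bear on it are the exchanges at the same phenyl ring: a 2.2-fold higher number from compound 1 to compound 2 (0.34 log units; beyond the scatter) and an at least 2.3-fold higher number from compound 1 to compound 3 (0.36 log units; beyond the scatter), both modest and both toward higher numbers, while an at least 1.0-fold higher number from compound 2 to compound 3 (0.02 log units; that floor lies within the scatter) shows no resolved difference between methoxy and ethoxy. Among the compounds with values here, compound 4 keeps a methoxy where compound 2 carries one and adds a second; no measured step tests a second methoxy. The expected step that the limit leaves unreadable from compound 3 to compound 4 is therefore no change beyond the scatter, with a fair chance that this assay again reports only a limit. Compound 4 is estimated at 55000 nM, within 25000 nM to 120000 nM.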

Compound 4, half-maximal inhibitory concentration: > 50000 nM
Compound 4: a limit, no number (the forecaster's own chance of this, stated with the estimate: 60%); the middle value lies beyond the limit too.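

In this assay compound 4 is reported only as a limit, > 50000 nM. The added second methoxy reads an at least 1.0-fold higher number from compound 2 to compound 4 (0.02 log units; that floor lies within the scatter), a floor that settles no order, while the exchange of the whole substituted phenyl group reads an at least 2.3-fold higher number from compound 1 to compound 4 (0.36 log units; beyond the scatter), so compound 1 keeps the lowest number of the set, with its steps to all three other compounds printed as beyond the scatter. The step between the two limits cannot be read, and a second compound now has no number of its own: the limit of > 50000 nM in this assay, at which 2 of the 4 values shown sit.

On these data alone, the order among compound 2, compound 3 and compound 4 stays open, as does the effect of a second methoxy on the phenyl ring. Also open, as far as these compounds go, is whether bromo, nitrile or a dimethylamino group in place of chloro on that ring would give a number equal to or lower than that of compound 1 in this assay.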